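The source may report more compounds than this note shows. Statements on the series, on what has been measured and on what is new or still open speak of the compounds shown alone.

Of the compounds shown here, three sharing one core have been measured in an assay (Cricetulus griseus) for inhibition of aldehyde dehydrogenase, mitochondrial (Homo sapiens); a higher number here means a weaker inhibitor, a lower number a stronger inhibitor. Compound 1 `CC(Oc1ccc2c(=O)c(-c3ccc(O)cc3)coc2c1)C(=O)O` gives 2500 nM. Compound 2 `CCCCCCC(Oc1ccc2c(=O)c(-c3ccc(O)cc3)coc2c1)C(=O)OCC` gives 7200 nM. Compound 3 `O=C(O)COc1ccc2c(=O)c(-c3ccc(O)cc3)coc2c1` gives 1200 nM, the lowest of the three numbers, so on these numbers compound 3 is the strongest inhibitor. Among the compounds with values here, the one step that can be read directly is a 2.1-fold lower number from compound 1 to compound 3 (0.32 log units; beyond the scatter): replacing the methyl by hydrogen on the saturated chain carbon bound to the carbonyl carbon and the oxygen on the aromatic ring made the inhibitor stronger by a modest amount.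

Compound 4 `CCCCCCC(Oc1ccc2c(=O)c(-c3ccc(O)cc3)coc2c1)C(=O)O` has not yet been measured. Compared with compound 3, the change is hexyl in place of hydrogen on a saturated chain carbon bound to a carbonyl carbon and an oxygen on an aromatic ring. The step from compound 1 to compound 3 bears on this, since it shows the number rising when even a methyl sits on that carbon. Within the data shown here, compound 2 also carries a hexyl chain there, together with an ethyl ester, and its value and that of compound 3 lie far apart; no single step joins them. A much longer chain is therefore expected to raise the number, and the expected step is a 4.2-fold higher number from compound 3 to compound 4 (0.62 log units; beyond the scatter). For compound 4 the estimate in this assay is 5000 nM, with a range from 2000 nM to 12000 nM.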

Compound 4, half-maximal inhibitory concentration: 2000 nM
Beside the measured number, compound 4's estimate is 2.5-fold (0.40 log units) above it; the measured number falls inside the stated range.
By their numbers in this assay, from the lowest: compounds 3, 4 and 1 (each within the scatter of the next, the first and the last beyond it); then compound 2.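

In this assay hexyl in place of hydrogen on this chain carbon gives a 1.7-fold higher number from compound 3 to compound 4 (0.22 log units; within the scatter) so this position takes a long chain without a clear loss of strength. Pentyl added to the end of the methyl gives a 1.3-fold lower number from compound 1 to compound 4 (0.10 log units; within the scatter) and so the numbers do not climb steadily with chain length. The weak result for compound 2 goes with its ethyl ester rather than its hexyl chain alone, since hydrogen in place of ethyl on an oxygen next to a carbonyl group gives a 3.6-fold lower number from compound 2 to compound 4 (0.56 log units; beyond the scatter) with the hexyl chain kept.

Nothing at hand explains why the hexyl chain fits here. Also open, going by these compounds, is whether a longer chain or an amine on this carbon would behave the same way, and whether an ethyl ester would weaken compound 3 as much.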